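Swapping the Aryl Group on the Ring Nitrogen

The source may hold more compounds than are shown below. What is called first, only, known or untested is meant among the compounds shown, and "the series" means these compounds.

Measured so far:
compound 1 `COc1ccc(N2NC3=CC[C@@H](OC)O[C@@]3(c3ccccc3)CC2=O)cc1`, 7100 nM
compound 2 `COc1cc(OC)cc(N2NC3=CC[C@@H](OC)O[C@@]3(c3ccccc3)CC2=O)c1`, 17300 nM

Both were tested in a functional assay on A549 cells (Homo sapiens) for inhibition, read by sulforhodamine B assay, with a stated time of 48 h; on this read-out higher numbers stand for weaker inhibition and lower numbers for stronger inhibition. Compound 1 gives 7100 nM, the lowest of the two numbers, while compound 2 gives 17300 nM, a higher number whose gap to compound 1 lies beyond the usual scatter. Going by the values given here, no pair of measured compounds differs in just one place, so no measured step is available to guide the next change. Compound 3 `CO[C@@H]1CC=C2NN(c3cncnc3)C(=O)C[C@]2(c2ccccc2)O1` has not yet been measured. It differs from compound 1 in one place: pyrimidin-5-yl in place of 4-methoxyphenyl on an amide-type nitrogen in a ring. Without a measured step of this kind, the outcome can only be read from the weak inhibition shown by compounds 1 and 2. The step of a 1.4-fold higher number from compound 1 to compound 3 (0.15 log units; within the scatter) is expected to be small, in either direction, or none beyond the scatter. Compound 3 is expected to give about 10000 nM, within a range from 3000 nM to 35000 nM.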

Compound 3, half-maximal inhibitory concentration: 5200 nM
Compound 3: the middle estimate sits 1.9-fold (0.28 log units) above what was measured; the measured number falls inside the stated range.
By their numbers in this assay, from the lowest: compounds 3 and 1 (each within the scatter of the next); then compound 2.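

In this assay, putting pyrimidin-5-yl in place of 4-methoxyphenyl on the amide-type nitrogen gives a 1.4-fold lower number from compound 1 to compound 3 (0.14 log units; within the scatter), so compound 1 and compound 3 cannot be told apart. Going by these compounds alone, this is the first measured one-place step at this nitrogen, and it shows that the carbon-only aromatic ring can be exchanged for an aromatic ring containing nitrogen without a change that stands out from the scatter. Nothing measured here explains why the number holds across this swap.

As far as these compounds go, both groups in this step are six-membered aromatic rings, so it remains open whether a non-aromatic group on this nitrogen, such as a cyclohexyl ring or a longer alkyl chain, would give a different number. The shared core also stays the same in these compounds, leaving open what an amine or a carboxylic acid on the phenyl group would do.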